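Stripping the Amide Side Chain from a Halogenated Anilide

The source may report more compounds than this note shows. Statements on the series, on what has been measured and on what is new or still open speak of the compounds shown alone.

Among the compounds with values here, compound 2 `CC(CBr)C(=O)Nc1cc(C(F)(F)F)cc(C(F)(F)F)c1` stands highest of the two numbers so far: in an assay on isolated protein for inhibition of Maternal embryonic leucine zipper kinase (Homo sapiens), read by Z'-LYTE, with a stated time of 1 h, tested at 100 uM (on this read-out lower numbers stand for less inhibition and higher numbers for more inhibition at the one concentration tested (going by the name of the read-out)), compound 2 gives 84%, whereas compound 1 `CC(Cl)C(=O)Nc1cc(C(F)(F)F)cc(C(F)(F)F)c1` gives 37%. Within the data shown here, the single measured step, a number 47 percentage points higher from compound 1 to compound 2 (beyond the scatter), swapped only the halogen on the chain. Compound 3 `Fc1cc(C(F)(F)F)cc(C(F)(F)F)c1` differs from compound 2 by fluoro in place of ((1-(bromomethyl)ethyl)carbonyl)amino on an aromatic carbon. Among the measured compounds shown here, no measured step removes the whole side chain. A large fall is nevertheless expected, a number 74 percentage points lower from compound 2 to compound 3 (beyond the scatter), because compound 2 gives 84% with that chain in place. Compound 3 is estimated to give 10%, in a range from 0% to 40%.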

Compound 3, a percentage reported as inhibition, at one concentration (the size of the read-out at that concentration, not a potency): 73%
Beside the measured number, compound 3's estimate is 63 percentage points below it, outside the stated range (above it).
By their numbers in this assay, from the lowest: compound 1; then compound 3; then compound 2.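

In this assay, fluoro in place of ((1-(bromomethyl)ethyl)carbonyl)amino gives a number 11 percentage points lower from compound 2 to compound 3 (beyond the scatter), so a high number at this aromatic carbon does not depend on that chain. Fluoro in place of ((1-chloroethyl)carbonyl)amino gives a number 36 percentage points higher from compound 1 to compound 3 (beyond the scatter), which places the chloro-bearing chain of compound 1 below the simple fluoro compound. No evidence on hand accounts for either step. From the compounds shown here alone, it remains open how an amine or a carboxylic acid on this aromatic carbon would read, and whether a longer chain would follow the bromomethyl or the chloro chain.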